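This account rests on a few compounds, and the source may have more. Where it says the series, first, only, none or still open, it means among the compounds named here.

Measured compounds:
compound 1 `COC(=O)[C@@]1(C)CCC=C2[C@@H]1CC[C@@H](C)[C@]2(C)Cc1c(C)[nH]c2ccc(C)cc12` with 18000 nM
compound 2 `COC(=O)[C@@]1(C)CCC=C2[C@@H]1CC[C@@H](C)[C@]2(C)Cc1c(C)[nH]c2ccc(F)cc12` with 12000 nM

In a functional assay on SW1573 cells (Homo sapiens) for inhibition, read by sulforhodamine B assay, with a stated time of 48 h (a lower number here means a stronger inhibitor of growth, a higher number a weaker inhibitor of growth), compound 2 gives 12000 nM. Among the compounds with values here, the only other number, that of compound 1, is 18000 nM, and the step of a 1.5-fold lower number from compound 1 to compound 2 (0.18 log units; within the scatter) lies within the scatter, so the two compounds cannot be told apart on these data.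

Compound 3 `COC(=O)[C@@]1(C)CCC=C2[C@@H]1CC[C@@H](C)[C@]2(C)Cc1c(C)[nH]c2ccc(OC)cc12` is made from compound 2 by the change (methoxy in place of fluoro on an aromatic carbon). Within the data shown here, the only measured step that bears on this position is the one between compound 1 and compound 2, where a methyl was replaced by a fluoro at the same aromatic carbon, and that step, a 1.5-fold lower number from compound 1 to compound 2 (0.18 log units; within the scatter), did not go beyond the scatter. Among the measured compounds shown here, no measured step brings in a methoxy, so there is nothing to suggest that this substituent would behave differently from the two already tested. For compound 3 the expected step is therefore a 1.2-fold higher number from compound 2 to compound 3 (0.07 log units; within the scatter), that is, no change beyond the scatter in this assay. Compound 3 is estimated at 14000 nM, with a range from 6000 nM to 35000 nM.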

Compound 3, concentration for 50% growth inhibition: 15000 nM
For compound 3 the middle estimate is 1.1-fold (0.03 log units) below the measured one; the measured number falls inside the stated range.
By their numbers in this assay, from the lowest: compounds 2, 3 and 1 (each within the scatter of the next).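

In this assay the aromatic carbon meta to a fused ring and para to a fused ring now carries a third group: methoxy in place of fluoro gives a 1.3-fold higher number from compound 2 to compound 3 (0.10 log units; within the scatter) and methoxy in place of methyl gives a 1.2-fold lower number from compound 1 to compound 3 (0.08 log units; within the scatter) on the same carbon. Within the data shown here, the methoxy brings in an oxygen and a hydrogen-bond acceptor, which neither the fluoro nor the methyl has, yet both steps stay within the scatter, so methyl, fluoro and methoxy at this carbon cannot be told apart in this read-out, where earlier only two groups could be set side by side. No measurement at hand offers an explanation for this sameness.

On these data alone, it remains open whether an amine, a carboxylic acid or a longer chain on this carbon would move the number beyond the scatter in this assay or stay with these three groups. As far as these compounds go, all three compounds share the rest of the core, and what a change elsewhere in that shared core would do also stays open.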